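Replacing the amide of compound 2 with a sulfonamide

The source may report more compounds than this note shows. Statements on the series, on what has been measured and on what is new or still open speak of the compounds shown alone.

Of the compounds shown here, three sharing one core have been tested in a functional assay on HCT-116 cells (Homo sapiens) for inhibition, read by luminescence and resazurin assay, with a stated time of 3 days; on this read-out lower numbers stand for stronger inhibition and higher numbers for weaker inhibition. Compound 1 `CCCNc1nc(NCc2ccc(NC(=O)c3ccc(F)cc3)cc2)c2ccccc2n1` gives 1700 nM in this assay. Compound 2 `CN1CCN(c2nc(NCc3ccc(NC(=O)c4ccc(F)cc4)cc3)c3ccccc3n2)CC1` gives 1800 nM, the highest of the three numbers, though the others lie close: the nearest is compound 1, with a 1.1-fold higher number from compound 1 to compound 2 (0.02 log units; within the scatter), and the furthest is compound 3 `CNc1nc(NCc2ccc(NC(=O)c3ccc(F)cc3)cc2)c2ccccc2n1`, which gives 1600 nM, with a 1.1-fold lower number from compound 2 to compound 3 (0.05 log units; within the scatter). Between compounds 1 and 3 the picture is the same, with a 1.1-fold lower number from compound 1 to compound 3 (0.03 log units; within the scatter). All three steps alter only the substituent on the core, and none of them reaches beyond the scatter.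

Compound 4 `Cc1ccc(S(=O)(=O)Nc2ccc(CNc3nc(N4CCN(C)CC4)nc4ccccc34)cc2)cc1` differs from compound 2 at the other end of the molecule: (4-methylphenyl)sulfonyl in place of (4-fluorophenyl)carbonyl on a nitrogen on an aromatic ring. Within the data shown here, none of the measured steps touches this part of the structure, so they offer no direct guide to the size of the change; they show only that the end carrying the amide has been kept the same in all three measured compounds. In the absence of any evidence on this position, the step expected from the change is a 1.7-fold higher number from compound 2 to compound 4 (0.22 log units; within the scatter), carrying a wide uncertainty. The estimate for compound 4 in this assay is 3000 nM, with a range from 800 nM to 12000 nM.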

Compound 4, half-maximal inhibitory concentration: > 20000 nM
Compound 4: no number, only a limit (the forecaster's own chance of this, stated with the estimate: 10%); middle value at least 6.6-fold (0.82 log units) from the limit.
By their numbers in this assay, from the lowest: compounds 3, 1 and 2 (each within the scatter of the next). At a limit, above all of these: compound 4.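

In this assay compound 4 carries > 20000 nM, which is a limit of the assay and not a number. The end of the molecule kept the same in compounds 1, 2 and 3 now proves to matter: (4-methylphenyl)sulfonyl in place of (4-fluorophenyl)carbonyl on a nitrogen on an aromatic ring gives an at least 11-fold higher number from compound 2 to compound 4 (1.04 log units; beyond the scatter), whereas every step among the substituents on the core stayed within the scatter. The change at this end therefore counts for far more in this series than the changes at the other end, but its full size cannot be read: the limit of > 20000 nM in this assay, at which 1 of the 4 values shown sits.

The compounds shown leave open which part of the change carries the step, the sulfonyl in place of the carbonyl or the methyl in place of the fluorine, and a (4-fluorophenyl)sulfonyl or a (4-methylphenyl)carbonyl group on this nitrogen would tell the two apart. On these data alone, it also remains open whether the sulfonamide end behaves the same way with propylamino or methylamino on the core in place of 4-methylpiperazin-1-yl.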